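Swapping an Ethoxy-Fluoro Ring for an Amino-Methoxy Ring

The compounds below may be only part of what the source reports. "The series", "measured", "known", "first", "only" and "open" are said of these compounds alone.

Compound 1 `COc1ccc(-c2cc3c(cn2)[nH]c(=O)n3-c2cc(OC)c(OC)c(OC)c2)cc1F`: 910 nM
Compound 2 `CCOc1ccc(-c2cc3c(cn2)[nH]c(=O)n3-c2cc(OC)c(OC)c(OC)c2)cc1F`: 7220 nM

For the measured compounds named here, in a functional assay on HCT-116 cells (Homo sapiens) for antiproliferative activity, read by MTT assay, with a stated time of 48 h (a higher number here means a weaker inhibitor, a lower number a stronger inhibitor), compound 2 gives 7220 nM, the higher of the two numbers measured so far. The next compound, compound 3 `COc1ccc(-c2cc3c(cn2)[nH]c(=O)n3-c2cc(OC)c(OC)c(OC)c2)cc1N`, has 3-amino-4-methoxyphenyl in place of 4-ethoxy-3-fluorophenyl on an aromatic carbon. Going by the values given here, one measured step bears on this change: a 7.9-fold higher number from compound 1 to compound 2 (0.90 log units; beyond the scatter), with ethoxy replacing methoxy. Compound 3 carries methoxy, as does compound 1 at 910 nM, so a lower number than for compound 2 is expected in this assay, by a step of similar size to the measured one. Among the compounds with values here, no measured compound carries an amino group, and this keeps the range wide. For compound 3, the expected value is 500 nM, within an estimated range of 60 nM to 4000 nM. The estimated change is a 14-fold lower number from compound 2 to compound 3 (1.16 log units; beyond the scatter).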

Compound 3, half-maximal inhibitory concentration: 820 nM
Compound 3: middle estimate off by 1.6-fold (0.21 log units), on the low side, and the stated range covers the measured number.
By their numbers in this assay, from the lowest: compounds 3 and 1 (each within the scatter of the next); then compound 2.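

Moving to 3-amino-4-methoxyphenyl from 4-ethoxy-3-fluorophenyl gives an 8.8-fold lower number from compound 2 to compound 3 (0.94 log units; beyond the scatter) in this assay and shows that this position accepts an amino group without any measured loss against the best numbers so far. The closer comparison is amino in place of fluoro with the methoxy group kept, which gives a 1.1-fold lower number from compound 1 to compound 3 (0.05 log units; within the scatter) and so leaves these two groups indistinguishable in this pair, while ethoxy in place of methoxy stands apart with a 7.9-fold higher number from compound 1 to compound 2 (0.90 log units; beyond the scatter) in the same assay. Nothing available here explains why amino and fluoro read alike on this ring.

As far as these compounds go, whether a methylamino or dimethylamino group would hold the same level remains open. So does whether compound 3 would keep its number with ethoxy in place of its methoxy group.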